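Swapping One Aromatic Group on a Shared Core

A few compounds are considered here, and "the series" means these few. Any claim that something is new, unique, unknown or untested is made for them only; others in the source may bear on it.

Of the compounds shown here, three that differ in a single aromatic group have been tested in an ADME assay (liver) for metabolic stability, with Liver microsome (Rattus norvegicus) as the target, using microsomes and NADPH, with a stated time of 30 min, tested at 1 uM; on this read-out higher numbers stand for fast clearance and lower numbers for slow clearance. Compound 1 `Nc1ccc(S(=O)(=O)N2CCN(c3ncc(C(O)(C(F)(F)F)C(F)(F)F)cc3-c3cccc(F)c3)CC2)cn1`, carrying 3-fluorophenyl, gives 52 mL.min-1.g-1. Compound 2 `NC(=O)c1cccc(-c2cc(C(O)(C(F)(F)F)C(F)(F)F)cnc2N2CCN(S(=O)(=O)c3ccc(N)nc3)CC2)c1`, carrying 3-carbamoylphenyl, gives 63 mL.min-1.g-1. Compound 3 `Nc1ccc(S(=O)(=O)N2CCN(c3ncc(C(O)(C(F)(F)F)C(F)(F)F)cc3-c3cnccc3F)CC2)cn1`, carrying 4-fluoropyridin-3-yl, gives 22 mL.min-1.g-1, the lowest of the three numbers.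

The next compound is compound 4 `Nc1ccc(S(=O)(=O)N2CCN(c3ncc(C(O)(C(F)(F)F)C(F)(F)F)cc3-c3ccc4sccc4c3)CC2)cn1`, in which 1-benzothiophen-5-yl takes the place of 4-fluoropyridin-3-yl: 1-benzothiophen-5-yl in place of 4-fluoropyridin-3-yl on an aromatic carbon.

Going by the values given here, three measured steps bear on this change. Exchanging fluoro for carbamoyl made no difference beyond the scatter: a 1.2-fold higher number from compound 1 to compound 2 (0.08 log units; within the scatter). Moving to the pyridine group mattered modestly: a 2.4-fold lower number from compound 1 to compound 3 (0.37 log units; beyond the scatter), and a 2.9-fold lower number from compound 2 to compound 3 (0.46 log units; beyond the scatter). Among these three compounds, the two with a carbon-only ring at this place sit above the one with a ring nitrogen, and none goes against that, though three compounds are little evidence. The group entering compound 4 also lacks a ring nitrogen, so a modest rise is expected, reversing the drop seen for compound 3 at 22 mL.min-1.g-1. The estimated step is a 3.2-fold higher number from compound 3 to compound 4 (0.50 log units; beyond the scatter). Among the compounds with values here, no measured compound has a two-ring group here, so the range stays wide. For compound 4 the expected value is 70 mL.min-1.g-1, with an estimated range of 33 mL.min-1.g-1 to 150 mL.min-1.g-1.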

Compound 4, intrinsic clearance in microsomes: 487 mL.min-1.g-1
Compound 4: the middle estimate sits 7.0-fold (0.84 log units) below what was measured; measured number above the stated range.
By their numbers in this assay, from the lowest: compound 3; then compounds 1 and 2 (each within the scatter of the next); then compound 4.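

In this assay, this place on the shared core proves far more sensitive than the single-ring swaps suggested, with the largest step of the set (a 22-fold higher number from compound 3 to compound 4 (1.35 log units; beyond the scatter)) arriving when 1-benzothiophen-5-yl replaces 4-fluoropyridin-3-yl. The missing ring nitrogen cannot be the whole story, since the two single carbon-only rings also lack one and the number still climbs from each of them, both for 3-fluorophenyl (a 9.4-fold higher number from compound 1 to compound 4 (0.97 log units; beyond the scatter)) and for 3-carbamoylphenyl (a 7.7-fold higher number from compound 2 to compound 4 (0.89 log units; beyond the scatter)). What lies behind this jump in clearance remains unexplained, with no supporting measurement available here.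

The compounds shown leave open whether the step follows from the sulfur, from the fused five-membered ring, or simply from a larger group of two rings, given that 1-benzothiophen-5-yl differs from all three earlier groups in each of these ways at once. A naphthalen-2-yl group, built of carbon only, and a quinolin-6-yl group, which carries a ring nitrogen, would help pull these apart at this same place.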